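The source may report more compounds than this note shows. Statements on the series, on what has been measured and on what is new or still open speak of the compounds shown alone.

Measured so far, in a functional assay on HL-60 cells (Homo sapiens) for antiproliferative activity, read by MTT assay, with a stated time of 48 h; on this read-out higher numbers stand for weaker inhibition and lower numbers for stronger inhibition:
compound 1 `CN(C)CCn1c(N)c(-c2nc3ccccc3[nH]2)c2nc(C#N)c(C#N)nc21`, 2220 nM
compound 2 `CN(C)CCCn1c(N)c(-c2nc3ccccc3[nH]2)c2nc(C#N)c(C#N)nc21`, 870 nM
compound 3 `CN(C)CCCn1c(N)c(-c2nc3ccccc3s2)c2nc(C#N)c(C#N)nc21`, 510 nM

Compound 2 differs from compound 1 by (dimethylamino)methyl in place of dimethylamino on a saturated chain carbon, two bonds along the chain from an aromatic nitrogen, and this one change gave a 2.6-fold lower number from compound 1 to compound 2 (0.41 log units; beyond the scatter). Compound 3 then differs from compound 2 in the ring attached to the core, and this gave a 1.7-fold lower number from compound 2 to compound 3 (0.23 log units; within the scatter), a gap too small to read as a real change. Compound 4 `CN(C)CCCCn1c(N)c(-c2nc3ccccc3s2)c2nc(C#N)c(C#N)nc21` has not yet been measured; it differs from compound 3 by (dimethylamino)methyl in place of dimethylamino on a saturated chain carbon, three bonds along the chain from an aromatic nitrogen. The difference between the cores of compound 1 and compound 3 is not broken down here. The change from compound 3 to compound 4 is the same kind of change as that from compound 1 to compound 2, not the same: there the place was two bonds along the chain from an aromatic nitrogen, here it is three bonds along. With the chain already one carbon longer, the step is expected to be smaller than a 2.6-fold lower number from compound 1 to compound 2 (0.41 log units; beyond the scatter), so for compound 4 in this assay a step of a 1.5-fold lower number from compound 3 to compound 4 (0.18 log units; within the scatter) is expected, resting on that single earlier step. Compound 4 is estimated at 340 nM, between 170 nM and 700 nM.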

Compound 4, half-maximal inhibitory concentration: 830 nM
Compound 4: middle estimate off by 2.4-fold (0.39 log units), on the low side, and the stated range ends below it.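

In this assay, putting 4-(dimethylamino)butyl in place of 3-(dimethylamino)propyl on the core of compound 3 gave a 1.6-fold higher number from compound 3 to compound 4 (0.21 log units; within the scatter), so this step cannot be read as a real change. Set beside the earlier step, the same change did not carry over with the same size from one core to the other: the same change on two cores in this assay, a 2.6-fold lower number (0.41 log units; beyond the scatter) from compound 1 to compound 2 and a 1.6-fold higher number (0.21 log units; within the scatter) from compound 3 to compound 4, 4.2-fold (0.62 log units) apart, beyond the scatter of two such steps

This shows that the gain seen on the first step cannot simply be assumed on another compound in this series, but it does not show why, since each result rests on a single pair and the two pairs differ both in the ring attached to the core and in where along the chain the change falls, two bonds along in one and three bonds along in the other.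

The compounds shown leave open how 4-(dimethylamino)butyl behaves alongside 1H-benzimidazol-2-yl, a comparison that could help separate the role of the ring from that of the chain length. They also leave open what a longer chain, or a morpholine in place of the dimethylamino group, would do in this series.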